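Swapping Fluoro for Chloro on the Aryl Ring

The source may hold more compounds than are shown below. What is called first, only, known or untested is meant among the compounds shown, and "the series" means these compounds.

Compound 1 `CCOC(=O)C1=C(C)N(c2ccc(C)cc2)C=CC1c1ccccc1` carries a methyl on its outer aromatic ring, and in a functional assay, tested at 200 ug/mL (a higher number here means a weaker effect of the compound at the concentration tested, a lower number a stronger effect), compound 1 gives -32.7%. Compound 2 `CCOC(=O)C1=C(C)N(c2ccc(F)cc2)C=CC1c1ccccc1` replaces that methyl with a fluoro, and in this assay compound 2 gives -25.5%. Within the data shown here, the only step available, a number 7.2 percentage points higher from compound 1 to compound 2 (within the scatter), shows how little the read-out moved. Compound 2 therefore stands as the higher of the two numbers, yet within the scatter of compound 1, so the two cannot be ranked.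

Compound 3 `CCOC(=O)C1=C(C)N(c2ccc(Cl)cc2)C=CC1c1ccccc1` differs from compound 2 by chloro in place of fluoro on an aromatic carbon. Among the measured compounds shown here, the single measured step at this same position, fluoro in place of methyl, stayed within the scatter, so a second exchange of one small halogen for another is expected to give no step beyond the scatter either, that is a number 1.5 percentage points lower from compound 2 to compound 3 (within the scatter). Compound 3 is accordingly estimated at -27%, with a likely range from -45% to -9%.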

Compound 3, a percentage reported as activity, at one concentration (the size of the read-out at that concentration, not a potency): -31.1%
The estimate for compound 3 lay 4.1 percentage points above the measured number; the measured number falls inside the stated range.
By their numbers in this assay, from the lowest: compounds 1, 3 and 2 (each within the scatter of the next).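

In this assay the exchange of fluoro for chloro gives a number 5.6 percentage points lower from compound 2 to compound 3 (within the scatter) and the exchange of methyl for chloro gives a number 1.6 percentage points higher from compound 1 to compound 3 (within the scatter) in this same series. The earlier compounds shown here offered a single step at this aromatic carbon, whereas three groups can now be compared there, and methyl, fluoro and chloro cannot be told apart by this read-out, so the position accepts all three with no step beyond the scatter. Nothing measured here explains why the three groups read alike.

From the compounds shown here alone, it remains open whether a group of a different kind at this carbon, such as an amine, a carboxylic acid or a longer chain, would move the read-out beyond the scatter. Going by these compounds, it also remains open whether the other positions of this ring would respond any differently.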